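This account rests on a few compounds, and the source may have more. Where it says the series, first, only, none or still open, it means among the compounds named here.

Compound 1 `Cc1cc(-c2ccc(=O)n(C)c2)cc2cn(C3CCNCC3)nc12` is the reference point here. In an assay on cells for displacement of a labelled ligand from Toll-like receptor 8 (Homo sapiens), read by TR-FRET, with a stated time of 30 min (on this read-out higher numbers stand for weaker inhibition and lower numbers for stronger inhibition), compound 1 gives 7600 nM, which places it second highest among the three numbers recorded: compound 3 `Cc1cc(=O)n(C)cc1-c1cc(C)c2nn(C3CCNCC3)cc2c1` gives 19000 nM, a step of a 2.5-fold higher number from compound 1 to compound 3 (0.40 log units; beyond the scatter), while compound 2 `Cc1cc(-c2cc(C)c3nn(C4CCNCC4)cc3c2)cn(C)c1=O` gives 1700 nM, a step of a 4.5-fold lower number from compound 1 to compound 2 (0.65 log units; beyond the scatter). Both measured steps are of the same kind, a methyl added on an aromatic carbon of the shared core of compound 1, yet they pull in opposite directions and are of only modest size.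

Compound 4 `Cc1cc(-c2ccc(=O)n(C)c2F)cc2cn(C3CCNCC3)nc12` has not yet been measured in this assay. It differs from compound 1 by fluoro in place of hydrogen on an aromatic carbon. Neither of the measured steps adds a fluorine, and neither touches the six-membered ring carrying a nitrogen where the change in compound 4 sits, so they bear only loosely on it; what they show is that a single small change on the core of compound 1 moved this assay by only a modest step, in either direction.

For compound 4 the change is therefore expected to be a 1.1-fold lower number from compound 1 to compound 4 (0.04 log units; within the scatter), with a number of 7000 nM estimated, in a range from 2500 nM to 20000 nM.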

Compound 4, half-maximal inhibitory concentration: 800 nM
The estimate for compound 4 lay 8.8-fold (0.94 log units) above the measured number; measured number outside the range, below it.
By their numbers in this assay, from the lowest: compound 4; then compound 2; then compound 1; then compound 3.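

In this assay one fluoro in place of hydrogen, a single heavy atom on an aromatic carbon next to the ring nitrogen, ortho to a large group and ortho to a methyl group, produced a 9.5-fold lower number from compound 1 to compound 4 (0.98 log units; beyond the scatter) as its step, so this carbon responds to a very small change. That step goes further than the largest lowering seen before, a 4.5-fold lower number from compound 1 to compound 2 (0.65 log units; beyond the scatter) for a methyl, and a small addition does not lower the number as a rule, since compound 3 goes against it with a 2.5-fold higher number from compound 1 to compound 3 (0.40 log units; beyond the scatter) as its step. No measurement given here bears on why the fluoro has this effect.

The compounds shown leave open whether the lower number belongs to fluoro itself or to any group on this carbon, as a chloro, a methyl, a methoxy or an amine there might show. They also leave open whether the fluoro of compound 4 and the methyl of compound 2 would combine in one molecule, and whether fluoro on other aromatic carbons of the shared core would do the same.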